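The source may report more compounds than this note shows. Statements on the series, on what has been measured and on what is new or still open speak of the compounds shown alone.

Measured compounds in a functional assay on CCRF-CEM cells (Homo sapiens) for cytotoxicity, in the presence of a further agent that is not named here; on this read-out higher numbers stand for weaker inhibition and lower numbers for stronger inhibition:
Compound 1 `CC(C)(C)OC(=O)CCC(Nc1ccc(CN(CCCc2c(N)nc(N)nc2O)c2ccc([N+](=O)[O-])c(F)c2[N+](=O)[O-])cc1)C(=O)OC(C)(C)C` gives 4000 nM.
Compound 2 `Nc1nc(N)c(CCCNc2cc(F)c([N+](=O)[O-])cc2[N+](=O)[O-])c(O)n1` gives 1200 nM.
Compound 3 `CC(C)(C)OC(=O)CCC(Nc1ccc(CN(CCCc2c(N)nc(N)nc2O)c2ccc([N+](=O)[O-])c(F)c2F)cc1)C(=O)OC(C)(C)C` gives 20000 nM.

Compound 1 and compound 3 share a core and differ in one place: fluoro in place of nitro on an aromatic carbon. This change gives a 5.0-fold higher number from compound 1 to compound 3 (0.70 log units; beyond the scatter), a step that lies beyond the usual scatter of this assay.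

Compound 2 has the lowest of the three measured numbers in this assay. The difference between the core of compound 2 and the core of compound 1 is not broken down here.

Compound 4 `Nc1nc(N)c(CCCNc2cc(F)c(F)cc2[N+](=O)[O-])c(O)n1` has not yet been measured. It differs from compound 2 in one place: fluoro in place of nitro on an aromatic carbon. Within the data shown here, this is the same kind of change as the one from compound 1 to compound 3, not the same one: in compound 1 the carbon that is changed is ortho to a large group and meta to a nitro group, whereas in compound 2 it is meta to a nitro group and para to a large group.

Among the measured compounds shown here, with only one measured example of this kind of change, the expectation for compound 4 rests on that single step. For the measured compounds named here, compound 4 is expected to show a 4.2-fold higher number from compound 2 to compound 4 (0.62 log units; beyond the scatter), a step of about the same size as the one from compound 1 to compound 3, because that step measured a 5.0-fold higher number from compound 1 to compound 3 (0.70 log units; beyond the scatter). Compound 4 is therefore estimated at 5000 nM in this assay, with a range from 2000 nM to 15000 nM.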

Compound 4, half-maximal inhibitory concentration: 97000 nM
Compound 4: the middle estimate sits 19-fold (1.29 log units) below what was measured, outside the stated range (above it).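

Putting fluoro in place of nitro on the core of compound 2 gives an 81-fold higher number from compound 2 to compound 4 (1.91 log units; beyond the scatter) in this assay. The change moves the number the same way on both cores, but the size of the step does not carry over from one core to the other: the same change on two cores in this assay, a 5.0-fold higher number (0.70 log units; beyond the scatter) from compound 1 to compound 3 and an 81-fold higher number (1.91 log units; beyond the scatter) from compound 2 to compound 4, 16-fold (1.21 log units) apart, beyond the scatter of two such steps. Among these compounds, this shows that a step measured on one core is a poor guide to its size on another, yet with only one pair on each core it does not show whether the gap follows from the core itself or from the place of the changed carbon, which differs between the two pairs, and it gives no reason for the gap.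

The compounds shown leave open whether an amine or a nitrile on that aromatic carbon would give a number closer to that of the nitro group in compound 2 or to that of the fluoro group in compound 4. They also leave open whether the difference between the two steps would persist with a longer chain in place of the propyl chain that links the two rings, or with a carboxylic acid in place of the esters of compound 1 and compound 3.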